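The source may report more compounds than this note shows. Statements on the series, on what has been measured and on what is new or still open speak of the compounds shown alone.

Compound 1 `CCN(C)c1cccc(NC(=O)C(=O)O)c1C#N`: 56.3%
Compound 2 `CC(C)Oc1cccc(NC(=O)C(=O)O)c1C#N`: 75.1%

Among the measured compounds shown here, in a functional assay on the whole organism for inhibition, with Rattus norvegicus as the target, at a dose of 1 mg/kg by the oral route (a higher number here means more inhibition at the dose given (going by the name of the read-out), a lower number less inhibition), compound 2 gives 75.1%, the higher of the two numbers measured so far. For the measured compounds named here, the one measured step, a number 18.8 percentage points higher from compound 1 to compound 2 (beyond the scatter), came from replacing ethyl(methyl)amino with isopropoxy on an aromatic carbon. Compound 3 `COC(=O)c1cccc(NC(=O)C(=O)O)c1C#N` changes that same position once more: methoxycarbonyl in place of isopropoxy on an aromatic carbon. The measured step bears on this change only in that it shows the read-out responding by a modest amount when the group at this position is exchanged; it involved neither of the groups exchanged here, so its direction cannot simply be carried over. A step of modest size in either direction, or none beyond the scatter, is plausible. As a middle estimate, compound 3 is expected to give 55% in this assay, within a range of 25% to 80%. The expected step is therefore a number 20.1 percentage points lower from compound 2 to compound 3 (beyond the scatter).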

Compound 3, a percentage reported as inhibition, in the whole organism at one dose (the size of the read-out at that dose, not a potency): 24.5%
The estimate for compound 3 lay 30.5 percentage points above the measured number; measured number outside the range, below it.
By their numbers in this assay, from the lowest: compound 3; then compound 1; then compound 2.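

Methoxycarbonyl in place of isopropoxy brings a number 50.6 percentage points lower from compound 2 to compound 3 (beyond the scatter) in this assay, and methoxycarbonyl in place of ethyl(methyl)amino brings a number 31.8 percentage points lower from compound 1 to compound 3 (beyond the scatter). This position on the aromatic ring, ortho to a cyano group, can therefore shift the read-out far more than the earlier modest step showed, and the change can be large even when the leaving and entering groups have the same heavy-atom count. Nothing measured here speaks to why the number falls.

Among the compounds shown here, with only three groups compared, it remains open which feature of methoxycarbonyl goes with the lower number. As far as these compounds go, a carboxylic acid, a primary amide or a longer alkoxy chain at this position could help separate the ester from the other groups, but how any of them would read is unknown.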